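The source may hold more compounds than are shown below. What is called first, only, known or untested is meant among the compounds shown, and "the series" means these compounds.

For the measured compounds named here, in an ADME assay on A549 cells (Homo sapiens) for cytotoxicity, read by resazurin assay, with a stated time of 48 h (a higher number here means that more compound is tolerated, a lower number that less compound is tolerated), compound 1 (`CC(=O)Nc1ccc(NC(=O)c2cc(Cl)ccc2O)c(Cl)c1`) has the entry "not determined" (no result reported), while compound 2 (`O=C(Nc1ccc(NC2CCCCC2)cc1Cl)c1cc(Cl)ccc1O`) gives 68300 nM, the only number available, with nothing measured to rank it against. Compound 3 (`O=C(Nc1ccc(N(CC2CC2)CC2CC2)cc1Cl)c1cc(Cl)ccc1O`) keeps the shared core and differs from compound 2 in one group: bis(cyclopropylmethyl)amino in place of cyclohexylamino on an aromatic carbon. Going by the values given here, no measured step shows what such a change does, and no shift beyond the usual scatter is expected in this assay. The expected change is a slight drop, a 1.2-fold lower number from compound 2 to compound 3 (0.09 log units; within the scatter). For compound 3 the estimated value is 55000 nM, with an expected range from 18000 nM to 150000 nM.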

Compound 3, half-maximal cytotoxic concentration: 12800 nM
Beside the measured number, compound 3's estimate is 4.3-fold (0.63 log units) above it; the measured number lies below the stated range.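

For the compounds shown here, putting bis(cyclopropylmethyl)amino in place of cyclohexylamino on this aromatic carbon gives the first readable step in this assay, a 5.3-fold lower number from compound 2 to compound 3 (0.73 log units; beyond the scatter). The group on this carbon therefore matters here, since this single exchange moves the number beyond the usual scatter. Nothing available explains the drop. One step cannot separate the loss of the hydrogen-bond donor from the change in ring size or heavy-atom count. As far as these compounds go, it also remains open whether a single cyclopropylmethylamino group would track compound 2 or compound 3, and what a carboxylic acid would do at this position.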